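The source may report more compounds than this note shows. Statements on the series, on what has been measured and on what is new or still open speak of the compounds shown alone.

Working notes on the series. In a functional assay on MDA-MB-231 cells (Homo sapiens) for antiproliferative activity, read by MTT assay, with a stated time of 24 h (a lower number here means a stronger inhibitor, a higher number a weaker inhibitor), compound 1 `O=C(O)CC(NS(=O)(=O)c1ccccc1)c1ccccc1` gives > 100000 nM as a limit of the assay. Compound 2 `CC(C)(C)c1ccc(C(CC(=O)O)NC(=O)c2c(Cl)cccc2Cl)cc1` gives > 100000 nM and this too is a limit. Compound 3 `CC(C)(C)c1ccc(C(CC(=O)O)NS(=O)(=O)c2ccccc2)cc1` gives > 100000 nM as a limit, so its place in the series is known only as a limit, shared with the other two values. Within the data shown here, no compound has yet returned a number.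

The change from compound 3 to compound 4 `CC(C)(C)c1ccc(C(CC(=O)O)NS(=O)(=O)c2ccc(OC(F)(F)F)cc2)cc1` is trifluoromethoxy in place of hydrogen on an aromatic carbon and it puts trifluoromethoxy in place of hydrogen on an aromatic carbon of a six-membered aromatic ring of carbon only, para to a large group.

Among the measured compounds shown here, only one measured step bears on this, and it is a different replacement of hydrogen on an aromatic carbon: a step that the two limits leave unreadable from compound 1 to compound 3 gives no size to carry over. The wider evidence is the limit of > 100000 nM in this assay, at which 3 of the 3 values shown sit, and it offers no measured gain either. In this assay the most likely result is therefore another limit, with only a small move toward a stronger inhibitor expected if a number appears. The estimated change is an at least 1.2-fold lower number from compound 3 to compound 4 (0.09 log units; that floor lies within the scatter) and it remains an expectation. For compound 4 the expected value is about 80000 nM with an estimated range from 20000 nM to 200000 nM in this assay.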

Compound 4, half-maximal inhibitory concentration: > 100000 nM
Compound 4 gave a limit, no number; the forecaster's own chance of this, stated with the estimate: 60%; middle value at least 1.2-fold (0.09 log units) from the limit.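

In this assay compound 4 gives > 100000 nM as a limit of the assay, not a number. Among these compounds, compound 3 also stands only at a limit, so no step between compound 3 and compound 4 can be read. The compounds shown leave open whether any change to the shared core returns a number at all: the limit of > 100000 nM in this assay, at which 4 of the 4 values shown sit.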